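A few compounds are considered here, and "the series" means these few. Any claim that something is new, unique, unknown or untested is made for them only; others in the source may bear on it.

In an assay on CHO cells for displacement of a labelled ligand from adenosine receptor A3 (Homo sapiens), read by scintillation counting, with a stated time of 3 h (a higher number here means a weaker inhibitor, a lower number a stronger inhibitor), three compounds have been measured so far:

Compound 1 `Cn1cc2c(Cl)nc(NC(=O)c3ccccc3)nc2n1`: 23600 nM
Compound 2 `CC(C)(C)Cn1cc2c(Cl)nc(NC(=O)c3ccccc3)nc2n1`: 30300 nM
Compound 3 `CC(C)n1cc2c(Cl)nc(NC(=O)c3ccccc3)nc2n1`: 12800 nM

Compound 2 shows the largest number of the three, but the step of a 1.3-fold higher number from compound 1 to compound 2 (0.11 log units; within the scatter) lies within the scatter, so compound 1 and compound 2 cannot be told apart on these data. Among the compounds with values here, only the step of a 2.4-fold lower number from compound 2 to compound 3 (0.37 log units; beyond the scatter) is beyond the scatter, and it is modest. Compound 4 `CC(C)(C)Cn1cc2c(Cl)nc(N)nc2n1` is the next compound, and it differs from compound 2 in one place: hydrogen in place of benzoyl on a nitrogen on an aromatic ring. Within the data shown here, every measured step so far, a 1.3-fold higher number from compound 1 to compound 2 (0.11 log units; within the scatter), a 1.8-fold lower number from compound 1 to compound 3 (0.27 log units; within the scatter) and a 2.4-fold lower number from compound 2 to compound 3 (0.37 log units; beyond the scatter), concerns the group on the other aromatic nitrogen of the shared core; none touches the benzoyl, so none bears directly on this change, and the expectation rests on the structural change alone and carries a wide range. Compound 4 is expected to give 60000 nM, between 15000 nM and 250000 nM. The expected step from compound 2 is a 2.0-fold higher number from compound 2 to compound 4 (0.30 log units; within the scatter), a higher number in this assay.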

Compound 4, inhibition constant: > 60000 nM
Compound 4: only a limit was reported (the forecaster's own chance of this, stated with the estimate: 40%); the middle value lies on the limit itself.
By their numbers in this assay, from the lowest: compounds 3, 1 and 2 (each within the scatter of the next, the first and the last beyond it). At a limit, above all of these: compound 4.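

Within the data shown here, the earlier compounds differ only in the group on the other aromatic nitrogen, so this is the first look at the nitrogen that carries the benzoyl. In this assay compound 4 gives a limit, not a number: > 60000 nM. From the compounds shown here alone, the change therefore reads as an at least 1.9-fold higher number from compound 2 to compound 4 (0.29 log units; that floor lies within the scatter), which shows that taking the benzoyl away does not give a lower number, while the true size of the step remains unknown.

Going by these compounds, it remains open whether the benzoyl itself matters or whether a smaller acyl group such as acetyl, or a longer one such as phenylacetyl, on that nitrogen would serve as well. On these data alone, it is also open whether the same change would read alike with the methyl of compound 1 or the isopropyl of compound 3 on the other aromatic nitrogen.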